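Notes on the series: replacing cyclopropyl with an aryl group

The compounds below may be only part of what the source reports. "The series", "measured", "known", "first", "only" and "open" are said of these compounds alone.

Three compounds share one core and differ only in the group on an aromatic carbon of the five-membered aromatic ring with one sulfur, two ring bonds from the ring sulfur. In a functional assay on cells for agonist activity at Free fatty acid receptor 1 (Rattus norvegicus), read by FLIPR and calcium flux (on this read-out lower numbers stand for an effect already at smaller amounts and higher numbers for an effect only at larger amounts of compound), compound 1 `CC#C[C@@H](Cc1nnn[nH]1)c1ccc(OCc2ccc3scc(-c4cc(OCCOC)ccc4C)c3c2)cc1` gives 26 nM, compound 2 `CC#C[C@@H](Cc1nnn[nH]1)c1ccc(OCc2ccc3scc(-c4ccc(OCCOC)cc4C)c3c2)cc1` gives 4 nM, and compound 3 `CC#C[C@@H](Cc1nnn[nH]1)c1ccc(OCc2ccc3scc(C4CC4)c3c2)cc1` gives 239 nM, the highest number of the three. The two steps that reach compound 3 are a 9.2-fold higher number from compound 1 to compound 3 (0.96 log units; beyond the scatter) and a 60-fold higher number from compound 2 to compound 3 (1.78 log units; beyond the scatter), so removing either substituted aryl group in favour of cyclopropyl raised the number beyond the scatter in both cases.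

Compound 4 `CC#C[C@@H](Cc1nnn[nH]1)c1ccc(OCc2ccc3scc(-c4ccccc4C(F)(F)F)c3c2)cc1` reverses that direction: 2-(trifluoromethyl)phenyl in place of cyclopropyl on an aromatic carbon. Both measured steps bear on it, as each swaps cyclopropyl against a phenyl ring bearing a methyl and a 2-methoxyethoxy group, whereas compound 4 carries a trifluoromethyl and no 2-methoxyethoxy chain. A lower number is therefore expected for compound 4 in this assay, with a step of roughly a 9.6-fold lower number from compound 3 to compound 4 (0.98 log units; beyond the scatter), smaller than the step back to compound 2 in view of the missing chain. The estimate for compound 4 is 25 nM, expected to fall between 6 nM and 100 nM.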

Compound 4, half-maximal effective concentration: 2 nM
Compound 4: middle estimate off by 13-fold (1.10 log units), on the high side; measured number below the stated range.
By their numbers in this assay, from the lowest: compounds 4 and 2 (each within the scatter of the next); then compound 1; then compound 3.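

In this assay, the step of a 2.0-fold lower number from compound 2 to compound 4 (0.30 log units; within the scatter) stays within the scatter, so a low number at this position on the five-membered ring does not require a 2-methoxyethoxy chain, and the aryl group of compound 4 carries none. The position of that chain matters only where it is present: the step of a 13-fold lower number from compound 1 to compound 4 (1.11 log units; beyond the scatter) lies beyond the scatter, and the step of a 120-fold lower number from compound 3 to compound 4 (2.08 log units; beyond the scatter) shows that the full gain over cyclopropyl is reached with 2-(trifluoromethyl)phenyl alone. Nothing measured here gives a reason for these steps.

As far as these compounds go, it remains open how much of the gain belongs to the phenyl ring and how much to the trifluoromethyl group, which a plain phenyl group would help to separate. From the compounds shown here alone, it is also open whether an amine or a carboxylic acid on this aryl ring would keep the number low.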